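A few compounds are considered here, and "the series" means these few. Any claim that something is new, unique, unknown or untested is made for them only; others in the source may bear on it.

Working notes on the hydrazone series in a functional assay on HT-29 cells (Homo sapiens) for cytotoxicity, read by MTT assay, with a stated time of 72 h; on this read-out higher numbers stand for weaker inhibition and lower numbers for stronger inhibition.

Compound 1 `CN(C)CCn1cnnc1-c1cc(Oc2ccc(NC(=O)N/N=C/c3ccc(O)c(F)c3)cc2F)ccn1` gives 3310 nM. Compound 2 `CN(C)CCn1cnnc1-c1cc(Oc2ccc(NC(=O)N/N=C/c3ccc(O)c(O)c3)cc2F)ccn1` gives 1890 nM. Among the compounds with values here, compound 3 `CN(C)CCn1cnnc1-c1cc(Oc2ccc(NC(=O)N/N=C/c3ccc(O)cc3)cc2F)ccn1` gives 1920 nM; on the numbers so far it is second highest of the three, and all three lie within the scatter of one another, so no order among them can be claimed. The steps measured: a 1.8-fold lower number from compound 1 to compound 2 (0.24 log units; within the scatter); a 1.7-fold lower number from compound 1 to compound 3 (0.24 log units; within the scatter); a 1.0-fold higher number from compound 2 to compound 3 (0.01 log units; within the scatter).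

Compound 4 `CN(C)CCn1cnnc1-c1cc(Oc2ccc(NC(=O)N/N=C/c3cc(Br)c(O)c(Br)c3)cc2F)ccn1` is the next in line. It differs from compound 3 as follows: 3,5-dibromo-4-hydroxyphenyl in place of 4-hydroxyphenyl on a carbon with a double bond to nitrogen. Within the data shown here, the steps that bear on this change are those on the same ring, with fluoro set against hydroxy and hydrogen in compounds 1, 2 and 3; each of them stayed within the scatter. Dibromination of the ring that carries the hydroxy is a larger change than any so far, yet nothing measured points in either direction. Among the measured compounds shown here, the expectation for compound 4 in this assay is therefore no step beyond the scatter, a 1.0-fold higher number from compound 3 to compound 4 (0.02 log units; within the scatter), with a wide range kept because the two bromines have no precedent here. Compound 4 is estimated at 2000 nM, between 700 nM and 6000 nM.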

Compound 4, half-maximal inhibitory concentration: 2670 nM
Compound 4: middle estimate off by 1.3-fold (0.13 log units), on the low side; the measured number falls inside the stated range.
By their numbers in this assay, from the lowest: compounds 2, 3, 4 and 1 (each within the scatter of the next).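

In this assay, the largest group shown at this place still gives no step beyond the scatter: 3,5-dibromo-4-hydroxyphenyl in place of 4-hydroxyphenyl gives a 1.4-fold higher number from compound 3 to compound 4 (0.14 log units; within the scatter). The same group set against 3,4-dihydroxyphenyl gives a 1.4-fold higher number from compound 2 to compound 4 (0.15 log units; within the scatter), and against 3-fluoro-4-hydroxyphenyl it gives a 1.2-fold lower number from compound 1 to compound 4 (0.09 log units; within the scatter), so all four groups on the carbon with a double bond to nitrogen now lie within the scatter of one another, including the one carrying two bromine atoms. No measurement at hand accounts for this flat read-out.

Every compound shown keeps the hydroxy on this ring, so it remains open how an amine or a carboxylic acid in its place would read. As far as these compounds go, whether any group at this place can produce a step beyond the scatter also remains open.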